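The compounds below may be only part of what the source reports. "The series", "measured", "known", "first", "only" and "open" are said of these compounds alone.

In a functional assay on MCF7 cells (Homo sapiens) for antiproliferative activity, read by MTT assay, with a stated time of 24 h (a lower number here means a stronger inhibitor, a higher number a weaker inhibitor), compound 1 (`CCCCc1oc2ccccc2c1C(=O)c1ccc(OCC(=O)NC(C)C)cc1`) gives > 50000 nM, which is a limit and not a number. Compound 2 (`CCCCc1oc2ccccc2c1C(=O)c1ccc(OCC(=O)N2CCCCC2)cc1`) gives > 50000 nM, which is likewise a limit. Both measured compounds therefore share one position on the scale, (the limit of > 50000 nM in this assay, at which 2 of the 2 values shown sit), and neither can be placed against the other.

Compound 3 (`CCCCc1oc2ccccc2c1C(=O)c1ccc(OCC(=O)N2CCOCC2)cc1`) keeps the shared core and the chain of compound 2 and changes only the amine part of the amide, with morpholin-4-yl in place of piperidin-1-yl on a carbonyl carbon. Among the compounds with values here, the one measured step at this same place is a step that the two limits leave unreadable from compound 1 to compound 2. That step replaces a different group and has no size that can be carried over, so the data offer no sign of any substituent at this carbonyl carbon producing measurable activity.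

No step beyond the scatter is therefore expected in this assay, and the estimated step is a number no higher from compound 2 to compound 3 (the limit leaves the size open). Compound 3 is expected to sit near 50000 nM, with an estimated range from 20000 nM to 100000 nM, and it will most likely be reported only as a limit.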

Compound 3, half-maximal inhibitory concentration: 34000 nM
Estimate against measurement, compound 3: 1.5-fold (0.17 log units) above, within the range that was stated.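

In this assay compound 3 gives 34000 nM, the first number among the compounds shown rather than a limit, so a group on this carbonyl carbon can now be placed on the scale. Morpholin-4-yl in place of piperidin-1-yl gives an at least 1.4-fold lower number from compound 2 to compound 3 (0.16 log units; that floor lies within the scatter), and morpholin-4-yl in place of isopropylamino gives an at least 1.4-fold lower number from compound 1 to compound 3 (0.16 log units; that floor lies within the scatter), so each change has a floor but no full size, and neither floor shows a change beyond the scatter. Compound 1 and compound 2 remain at a limit of the assay: the limit of > 50000 nM in this assay, at which 2 of the 3 values shown sit.

From the compounds shown here alone, the full size of both steps remains open, and the step between the two compounds held at the limit cannot be read. Going by these compounds, it is also open whether a piperazin-1-yl, a thiomorpholin-4-yl or a pyrrolidin-1-yl group on this carbonyl carbon would give a number or a limit, and whether a longer chain on the shared core would shift the reading of compound 3 in this assay.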